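The compounds below may be only part of what the source reports. "The series", "measured", "known", "first", "only" and "open" are said of these compounds alone.

The measured compounds:
Compound 1 `CN(C)CCNc1nc(-c2ccc(NC(=O)Nc3ccc(F)cc3)cc2)nc2c(Cl)c(Cl)sc12` gives 1350 nM in a functional assay on MKN-45 cells (Homo sapiens) for cytotoxicity, read by MTT assay, with a stated time of 72 h; a higher number here means a weaker inhibitor, a lower number a stronger inhibitor.
Compound 2 `CN(C)CCNc1nc(-c2ccc(NC(=O)Nc3ccc(Cl)cc3)cc2)nc2c(Cl)c(Cl)sc12` gives 910 nM.
Compound 3 `CN(C)CCNc1nc(-c2ccc(NC(=O)Nc3ccccc3Cl)cc2)nc2c(Cl)c(Cl)sc12` gives 1170 nM.

Compound 3 holds the second highest of these three numbers; compound 1 is its nearest neighbour and compound 2 its furthest, with both gaps within the scatter (a 1.2-fold lower number from compound 1 to compound 3 (0.06 log units; within the scatter); a 1.3-fold higher number from compound 2 to compound 3 (0.11 log units; within the scatter)). Compound 4 `CN(C)CCNc1nc(-c2ccc(NC(=O)Nc3ccc(Cl)cc3Cl)cc2)nc2c(Cl)c(Cl)sc12` differs from compound 3 by chloro in place of hydrogen on an aromatic carbon. Among the compounds with values here, no measured step puts a chloro where a hydrogen stood. Within the data shown here, the steps that bear on it are a 1.5-fold lower number from compound 1 to compound 2 (0.17 log units; within the scatter), a chloro in place of fluoro, and a 1.3-fold higher number from compound 2 to compound 3 (0.11 log units; within the scatter), which moved the single chloro. Both stayed within the scatter, so no step beyond the scatter is expected in this assay. Compound 4 is therefore estimated at 950 nM, in the range 450 nM to 2000 nM, meaning an expected step of a 1.2-fold lower number from compound 3 to compound 4 (0.09 log units; within the scatter).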

Compound 4, half-maximal inhibitory concentration: 3460 nM
Beside the measured number, compound 4's estimate is 3.6-fold (0.56 log units) below it; measured number outside the range, above it.
By their numbers in this assay, from the lowest: compounds 2, 3 and 1 (each within the scatter of the next); then compound 4.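

In this assay a second chloro on the aromatic ring gives a 3.0-fold higher number from compound 3 to compound 4 (0.47 log units; beyond the scatter) and also a 3.8-fold higher number from compound 2 to compound 4 (0.58 log units; beyond the scatter), so this carbon, para to a large group, responds to added chloro in a way the earlier single-halogen changes, all within the scatter, did not show. The 2,4-dichlorophenyl group likewise departs from 4-fluorophenyl, with a 2.6-fold higher number from compound 1 to compound 4 (0.41 log units; beyond the scatter) as the step. No evidence here accounts for this rise. From the compounds shown here alone, whether it belongs to chloro specifically or to any second group remains open: a methyl, methoxy or amino group on the same carbon would separate the two.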